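Swapping the naphthalene for a chlorophenyl on the amine side

The compounds below may be only part of what the source reports. "The series", "measured", "known", "first", "only" and "open" are said of these compounds alone.

Two compounds share a core that carries a sulfonamide on one end and a benzyl-type amine on the other. Compound 1 `O=S(=O)(NCCCNCc1ccccc1Cl)c1cc(C(F)(F)F)cc(C(F)(F)F)c1` gives 13000 nM in a functional assay on ASPC1 cells (Homo sapiens) for inhibition, read by MTT assay, with a stated time of 72 h; on this read-out higher numbers stand for weaker inhibition of growth and lower numbers for stronger inhibition of growth. Among the compounds with values here, compound 2 `O=S(=O)(NCCCNCc1cccc2ccccc12)c1cc(C(F)(F)F)cc(C(F)(F)F)c1` gives 21000 nM in this assay, which puts compound 2 at the highest of the two numbers so far, though the step of a 1.6-fold higher number from compound 1 to compound 2 (0.21 log units; within the scatter) is within the scatter, so the two values cannot be told apart.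

Compound 3 `O=S(=O)(NCCCNCc1ccc(Cl)cc1)c1cc(C(F)(F)F)cc(C(F)(F)F)c1` is the unmeasured compound. It differs from compound 2 by 4-chlorophenyl in place of naphthalen-1-yl on a saturated chain carbon bound to an amine nitrogen. Within the data shown here, the only measured step that bears on this change is the one from compound 1 to compound 2, where a chlorophenyl was exchanged for the naphthalen-1-yl group, and that step stayed within the scatter. Since the move back to a chlorophenyl, now bearing the chlorine at the 4-position, mirrors that exchange, the step of a 1.5-fold lower number from compound 2 to compound 3 (0.18 log units; within the scatter) is expected to stay within the scatter as well. Compound 3 is therefore estimated to give 14000 nM in this assay, with a range from 6000 nM to 35000 nM.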

Compound 3, concentration for 50% growth inhibition: 3000 nM
Compound 3: the middle estimate sits 4.7-fold (0.67 log units) above what was measured; the whole stated range lies above it.
By their numbers in this assay, from the lowest: compound 3; then compounds 1 and 2 (each within the scatter of the next).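

This result shows that the group on the saturated chain carbon bound to an amine nitrogen can change the read-out: in this assay there is a 7.0-fold lower number from compound 2 to compound 3 (0.85 log units; beyond the scatter) when 4-chlorophenyl takes the place of naphthalen-1-yl, whereas the earlier pair of compounds could not be told apart. It also shows that where the chlorine sits on the phenyl ring counts in this small set, since moving from 2-chlorophenyl to 4-chlorophenyl gives a 4.3-fold lower number from compound 1 to compound 3 (0.64 log units; beyond the scatter) even though the two groups hold the same atoms. Among these three compounds, then, only the 4-chlorophenyl group stands apart, and nothing available here explains why.

The compounds shown leave open whether the chlorine itself is needed, as a plain phenyl, a 4-fluorophenyl or a 4-methoxyphenyl group at this position could give a quite different number. They also leave open whether the gain seen with 4-chlorophenyl would survive a longer chain in the shared core, or a replacement of either trifluoromethyl group by a nitrile.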